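Triazolylmethyl spiro-oxindoles: antiproliferative readout on endothelial cells

The compounds below may be only part of what the source reports. "The series", "measured", "known", "first", "only" and "open" are said of these compounds alone.

Measured so far in an ADME assay on HUVEC cells (Homo sapiens) for antiproliferative activity, read by MTT assay, with a stated time of 48 h; a higher number here means a weaker inhibitor, a lower number a stronger inhibitor: compound 1 `N#CC1=C(N)Oc2c(N)cc3nc4ccccc4nc3c2C12C(=O)N(Cc1cnnn1-c1ccc(Cl)cc1)c1ccccc12` and compound 2 `COc1ccc(OC)c(-n2nncc2CN2C(=O)C3(C(C#N)=C(N)Oc4c(N)cc5nc6ccccc6nc5c43)c3ccccc32)c1`.

In this assay compound 1 gives > 50000 nM, a limit of the assay rather than a number. Compound 2 gives > 50000 nM in this assay, likewise a limit. The step that the two limits leave unreadable from compound 1 to compound 2 is therefore unreadable. Compound 2 thus stands at the limit, as does compound 1 (the limit of > 50000 nM in this assay, at which 2 of the 2 values shown sit).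

Compound 3 `Cc1ccc(-n2nncc2CN2C(=O)C3(C(C#N)=C(N)Oc4c(N)cc5nc6ccccc6nc5c43)c3ccccc32)cc1Cl` carries 3-chloro-4-methylphenyl in place of 2,5-dimethoxyphenyl on an aromatic nitrogen. Within the data shown here, the only measured step bears on this change solely in that both of its ends sit at the limit (the limit of > 50000 nM in this assay, at which 2 of the 2 values shown sit); no sized step is available. Compound 3 is therefore expected also to sit at the limit, with an estimated 80000 nM (range 30000 nM to 300000 nM). The expected step is a step that the limit leaves unreadable from compound 2 to compound 3, not beyond the scatter.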

Compound 3, half-maximal inhibitory concentration: > 50000 nM
Compound 3 ended at the assay's limit; the forecaster's own chance of this, stated with the estimate: 85%; the middle value lies beyond the limit too.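

Compound 1, compound 2 and compound 3 all sit at the same limit, so no step among them can be read: the limit of > 50000 nM in this assay, at which 3 of the 3 values shown sit.

As far as these compounds go, whether any group on that aromatic nitrogen gives a measurable value in this assay remains open.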